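Oxime ether series: chain extension from compound 1

This account rests on a few compounds, and the source may have more. Where it says the series, first, only, none or still open, it means among the compounds named here.

Measured so far:
compound 1, `CCO/N=C/c1c(N)ncnc1Oc1ccc(NC(=O)C2(C(=O)Nc3ccc(F)cc3)CC2)cc1F`: 3.41
compound 2, `C#CCO/N=C/c1c(N)ncnc1Oc1ccc(NC(=O)C2(C(=O)Nc3ccc(F)cc3)CC2)cc1F`: 3.34
compound 3, `Nc1ncnc(Oc2ccc(NC(=O)C3(C(=O)Nc4ccc(F)cc4)CC3)cc2F)c1/C=N/OC1CCCCC1`: 4.69

In a physicochemical assay for lipophilicity, using the shake flask method (a lower number here means a more polar compound, a higher number a more lipophilic compound), compound 1 stands second highest of the three, with compound 2 closest and compound 3 furthest away. The step of a number 0.07 log units lower from compound 1 to compound 2 (within the scatter) shows that a small alteration on the chain attached to the oxime oxygen leaves this assay essentially unchanged. By contrast, a number 1.28 log units higher from compound 1 to compound 3 (beyond the scatter) and a number 1.35 log units higher from compound 2 to compound 3 (beyond the scatter) show that replacing the short chain with a saturated ring moves this assay strongly upward.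

Compound 4, `COCCCO/N=C/c1c(N)ncnc1Oc1ccc(NC(=O)C2(C(=O)Nc3ccc(F)cc3)CC2)cc1F`, differs from compound 1 by methoxymethyl in place of hydrogen on a saturated chain carbon, two bonds along the chain from an oxygen on an unsaturated carbon. No ring enters here, so the large steps toward compound 3 are not a direct guide; the change is closer in kind to the chain alteration from compound 1 to compound 2, which stayed within the scatter. A step of about a number 0.09 log units higher from compound 1 to compound 4 (within the scatter) is therefore expected, likely within the scatter. For compound 4 the estimate in this assay is 3.5, with a range from 3.1 to 3.9.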

Compound 4, partition coefficient: 3.18
Beside the measured number, compound 4's estimate is 0.32 log units above it; the range from low to high includes it.
By their numbers in this assay, from the lowest: compounds 4, 2 and 1 (each within the scatter of the next); then compound 3.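

In this assay, lengthening the chain on the oxime oxygen to 3-methoxypropyl gives a number 0.23 log units lower from compound 1 to compound 4 (within the scatter) and, against the propargyl chain, a number 0.16 log units lower from compound 2 to compound 4 (within the scatter), so the added methoxymethyl does not separate compound 4 from the two shorter chains. Among the four compounds, only the cyclohexyl group stands apart at this position, now also against a long open chain, with a number 1.51 log units lower from compound 3 to compound 4 (beyond the scatter). Nothing available gives a cause for this result.

The compounds shown leave open whether the ether oxygen matters here, since a pentyl chain of similar length would be needed to separate chain length from that oxygen. They also leave open how a chain ending in an amine or a carboxylic acid, or a smaller ring such as cyclopropyl, would read in this assay.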